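Moving the halogens on the second benzylidene ring

The compounds below may be only part of what the source reports. "The series", "measured", "known", "first", "only" and "open" are said of these compounds alone.

Measured compounds:
Compound 1 `C=CCn1c(=O)/c(=C\c2cccc(Cl)c2Cl)[nH]c(=O)/c1=C\c1ccccc1OC`: 2300 nM
Compound 2 `C=CCn1c(=O)/c(=C\c2ccc(Cl)c(Cl)c2)[nH]c(=O)/c1=C\c1ccccc1OC`: "not active" (no number reported)
Compound 3 `C=CCn1c(=O)/c(=C\c2cc(Br)ccc2F)[nH]c(=O)/c1=C\c1ccccc1OC`: "not active" (no number reported)

In a functional assay on A549 cells (Homo sapiens) for cytotoxicity, read by CCK-8 assay, with a stated time of 72 h (on this read-out higher numbers stand for weaker inhibition and lower numbers for stronger inhibition), compound 1 gives 2300 nM. Compound 2 is reported as "not active" (no number reported), with no number. Compound 3 is likewise reported as "not active" (no number reported), so it stands without a number and cannot be ranked against compound 1. Compound 4 `C=CCn1c(=O)/c(=C\c2ccc(F)c(Br)c2)[nH]c(=O)/c1=C\c1ccccc1OC` keeps the same atoms but carries 3-bromo-4-fluorophenyl in place of 5-bromo-2-fluorophenyl on a double-bonded chain carbon bound to an aromatic carbon. Going by the values given here, no measured pair shows this kind of rearrangement, so the size of the step is unknown; since compound 3 and compound 2 both give no number, only a weak effect is expected for compound 4, with a fair chance that this assay again reports no number. Compound 4 is estimated at 20000 nM, within 5000 nM to 80000 nM.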

Compound 4, half-maximal inhibitory concentration: "not active" (no number reported)
For compound 4 the study gives words and no number; there is nothing to compare the estimate with.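

In this assay compound 3 and compound 4 both stand without a number, so no step can be read between them. No evidence here bears on this result. The compounds shown leave open whether exchanging 5-bromo-2-fluorophenyl for 3-bromo-4-fluorophenyl changes activity at all.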